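Amino in place of nitro: what to expect

A few compounds are considered here, and "the series" means these few. Any claim that something is new, unique, unknown or untested is made for them only; others in the source may bear on it.

Three compounds have been measured in a functional assay on A2780 cells (Homo sapiens) for cytotoxicity, read by MTT assay, with a stated time of 48 h; on this read-out higher numbers stand for weaker inhibition and lower numbers for stronger inhibition:
Compound 1, `CCn1cc(-c2nc3ccccc3[nH]2)c(=O)c2cc(F)c(N3CCNCC3)cc21`: 800 nM
Compound 2, `CCn1cc(-c2nc3ccc(Cl)cc3[nH]2)c(=O)c2cc(F)c(N3CCNCC3)cc21`: 4900 nM
Compound 3, `CCn1cc(-c2nc3ccc([N+](=O)[O-])cc3[nH]2)c(=O)c2cc(F)c(N3CCNCC3)cc21`: 1600 nM

Compound 3 stands second highest of these three numbers. The step of a 2.0-fold higher number from compound 1 to compound 3 (0.30 log units; within the scatter) lies within the scatter, whereas a 3.1-fold lower number from compound 2 to compound 3 (0.49 log units; beyond the scatter) lies beyond it. Compound 4, `CCn1cc(-c2nc3ccc(N)cc3[nH]2)c(=O)c2cc(F)c(N3CCNCC3)cc21`, differs from compound 3 by amino in place of nitro on an aromatic carbon. Among the measured compounds shown here, no measured step involves amino, so only the two steps that end at compound 3 bear on this change, and both were small to modest. Compound 4 is therefore expected to sit close to compound 3 in this assay, with a 1.6-fold lower number from compound 3 to compound 4 (0.20 log units; within the scatter) estimated as lying within the scatter. The estimate for compound 4 is 1000 nM, in a range from 400 nM to 2500 nM.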

Compound 4, half-maximal inhibitory concentration: 51500 nM
Compound 4: the middle estimate sits 52-fold (1.71 log units) below what was measured, outside the stated range (above it).
By their numbers in this assay, from the lowest: compounds 1 and 3 (each within the scatter of the next); then compound 2; then compound 4.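

In this assay amino gives the weakest inhibition of the four compounds (a 32-fold higher number from compound 3 to compound 4 (1.51 log units; beyond the scatter); an 11-fold higher number from compound 2 to compound 4 (1.02 log units; beyond the scatter); a 64-fold higher number from compound 1 to compound 4 (1.81 log units; beyond the scatter)). The earlier steps shown here among hydrogen, chloro and nitro were modest at most, so this position can respond far more sharply than those three groups suggested. No measurement available here accounts for the change. From the compounds shown here alone, it remains open whether a methylamino group or an acetamide at this position would stay close to compound 4 or move back towards compound 1.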